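A Methoxy Group Added to Compound 1

This account rests on a few compounds, and the source may have more. Where it says the series, first, only, none or still open, it means among the compounds named here.

Among the compounds with values here, in a functional assay on A549 cells (Homo sapiens) for antiproliferative activity, read by MTT assay, with a stated time of 48 h (on this read-out higher numbers stand for weaker inhibition and lower numbers for stronger inhibition), compound 1 `Cc1cc2nc(-c3cn(-c4ccccc4)nc3-c3ccccc3)[nH]c2cc1C` gives 14500 nM, the highest of the three numbers measured so far. Compound 2 `Clc1ccc(-c2nn(-c3ccccc3)cc2-c2nc3cc(Cl)ccc3[nH]2)cc1` gives 1340 nM and compound 3 `COc1ccc(-c2nn(-c3ccccc3)cc2-c2nc3cc(C(F)(F)F)ccc3[nH]2)cc1` gives 4820 nM, both lower than compound 1 by more than the scatter. Compound 4 `COc1ccc(-c2nn(-c3ccccc3)cc2-c2nc3cc(C)c(C)cc3[nH]2)cc1` differs from compound 1 by methoxy in place of hydrogen on an aromatic carbon, a change from phenyl to 4-methoxyphenyl. Within the data shown here, no measured pair isolates this change. Among the measured compounds shown here, the only guide is compound 3, which also carries 4-methoxyphenyl and gives 4820 nM. A moderate move toward stronger inhibition in this assay is therefore expected, an estimated step of a 2.4-fold lower number from compound 1 to compound 4 (0.38 log units; beyond the scatter). For compound 4 the estimated value is 6000 nM, with an expected range of 2200 nM to 14000 nM.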

Compound 4, half-maximal inhibitory concentration: 5850 nM
Estimate against measurement, compound 4: 1.0-fold (0.01 log units) above, within the range that was stated.
By their numbers in this assay, from the lowest: compound 2; then compounds 3 and 4 (each within the scatter of the next); then compound 1.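

Within the data shown here, the first pair that isolates phenyl to 4-methoxyphenyl now stands: in this assay, methoxy in place of hydrogen on an aromatic carbon, para to a large group, gives a 2.5-fold lower number from compound 1 to compound 4 (0.39 log units; beyond the scatter) as a modest step. This position therefore accepts methoxy with a small move toward stronger inhibition, though this is one step on one background. Nothing measured here speaks to why the step arises.

Going by these compounds, whether an amine, a hydroxyl or a longer chain such as ethoxy at this position would move the number further remains open. So does whether methoxy brings a similar step on other substituted versions of the core.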